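The compounds below may be only part of what the source reports. "The series", "measured", "known", "first", "only" and "open" are said of these compounds alone.

Working notes on the series. In a functional assay on U2OS cells (Homo sapiens) for cytotoxicity, read by MTT assay, with a stated time of 48 h (on this read-out lower numbers stand for stronger inhibition and higher numbers for weaker inhibition), compound 1 `Fc1cccc(-c2nc(Nc3ccccc3Cl)c3cc(F)ccc3n2)c1` gives > 50000 nM, which is a limit of the assay and not a number. Within the data shown here, compound 2 `Nc1ccc(Nc2nc(-c3cccc(F)c3)nc3ccc(F)cc23)cc1` gives 44200 nM, the only actual number so far. Next in line is compound 3 `Cc1cccc(Nc2nc(-c3cccc(F)c3)nc3ccc(F)cc23)c1`, and the change is 3-methylphenyl in place of 4-aminophenyl on a nitrogen on an aromatic ring.

Among the measured compounds shown here, one measured step bears on this place, an at least 1.1-fold lower number from compound 1 to compound 2 (0.05 log units; that floor lies within the scatter). It exchanged 2-chlorophenyl for 4-aminophenyl on the same nitrogen, and its floor does not clear the scatter. The evidence is thin: the limit of > 50000 nM in this assay, at which 1 of the 2 values shown sits.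

For the measured compounds named here, with only that step to go on, no shift beyond the scatter is expected in this assay, and a report as a limit is about as likely as a number. The expected step is a 1.1-fold higher number from compound 2 to compound 3 (0.05 log units; within the scatter), which would stay within the scatter. For compound 3 the estimate is 50000 nM, with an expected range of 22000 nM to 100000 nM.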

Compound 3, half-maximal inhibitory concentration: > 50000 nM
Compound 3: only a limit was reported; the forecaster's own chance of this, stated with the estimate: 55%; the middle value sits exactly at the limit.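

In this assay, the change on this nitrogen gives an at least 1.1-fold higher number from compound 2 to compound 3 (0.05 log units; that floor lies within the scatter). From the compounds shown here alone, that floor does not clear the scatter, so exchanging 4-aminophenyl for 3-methylphenyl, which takes away the hydrogen-bond donor and acceptor counted for the leaving group, shows no measurable gain here, and the true size of the step stays unknown. The step from compound 1 to compound 3 cannot be read, as both values are limits. With 2-chlorophenyl and 3-methylphenyl both reported only as a limit, the upper end of the assay's range now holds most of the series: the limit of > 50000 nM in this assay, at which 2 of the 3 values shown sit.

Going by these compounds, all three compounds carry a substituted phenyl group on this nitrogen, so it remains open whether a phenyl ring bearing a carboxylic acid, or a longer chain such as benzyl, would bring the number down beyond the scatter. Also open is whether any change elsewhere on the shared core would move these values, since every compound shown differs only on this nitrogen.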